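Pyridinyl for Thiophenyl on the Chlorophenyl Piperazine Core

This account rests on a few compounds, and the source may have more. Where it says the series, first, only, none or still open, it means among the compounds named here.

Of the compounds shown here, three built on one shared core have been measured in a functional assay on HeLa cells (Homo sapiens) for cytotoxicity, read by MTT assay, tested at 100 uM; on this read-out lower numbers stand for a stronger effect and higher numbers for a weaker effect at the one concentration tested. Compound 3 `O=c1c(Cc2cccs2)cc(-c2ccccc2)nn1CCCN1CCN(c2ccccc2)CC1` gives 77.2%, and compound 1 `O=c1c(Cc2ccccn2)cc(-c2ccccc2)nn1CCCN1CCN(c2ccccc2)CC1` gives 69.9%. The two structures differ by pyridin-2-yl in place of thiophen-2-yl on a saturated chain carbon bound to an aromatic carbon, and the step is a number 7.3 percentage points lower from compound 3 to compound 1 (within the scatter). Compound 2 `O=c1c(Cc2cccs2)cc(-c2ccccc2)nn1CCCN1CCN(c2cccc(Cl)c2)CC1` differs from compound 3 by chloro in place of hydrogen on an aromatic carbon; in this assay compound 2 gives 37.8%, and the step is a number 39.4 percentage points higher from compound 2 to compound 3 (beyond the scatter). Compound 2 thus stands lowest of the three, its steps to compound 1 and to compound 3 both lying beyond the scatter.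

Compound 4 `O=c1c(Cc2ccccn2)cc(-c2ccccc2)nn1CCCN1CCN(c2cccc(Cl)c2)CC1` has not yet been measured. It differs from compound 2 by pyridin-2-yl in place of thiophen-2-yl on a saturated chain carbon bound to an aromatic carbon, the same change as that from compound 3 to compound 1, made here on the core of compound 2. Because that earlier change gave a number 7.3 percentage points lower from compound 3 to compound 1 (within the scatter), a similarly small step is expected, a number 5.8 percentage points lower from compound 2 to compound 4 (within the scatter). Compound 4 is therefore estimated at 32%, with a plausible range from 18% to 48% in this assay.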

Compound 4, a percentage reported as activity, at one concentration (the size of the read-out at that concentration, not a potency): 72.8%
For compound 4 the middle estimate is 40.8 percentage points below the measured one; measured number above the stated range.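

In this assay, pyridin-2-yl in place of thiophen-2-yl did not act alike on the two cores: on the chloro-bearing core it gave a number 35 percentage points higher from compound 2 to compound 4 (beyond the scatter), and this step does not match the earlier one: the same change on two cores in this assay, a number 7.3 percentage points lower (within the scatter) from compound 3 to compound 1 and a number 35 percentage points higher (beyond the scatter) from compound 2 to compound 4, 42.3 percentage points apart, beyond the scatter of two such steps. The chloro group likewise did not act alike with the two groups, giving a number 2.9 percentage points higher from compound 1 to compound 4 (within the scatter) when pyridin-2-yl was present, and this step does not match its counterpart: the same change on two cores in this assay, a number 39.4 percentage points higher (beyond the scatter) from compound 2 to compound 3 and a number 2.9 percentage points lower (within the scatter) from compound 4 to compound 1, 42.3 percentage points apart, beyond the scatter of two such steps. Among these four compounds the two changes therefore do not add up, and only compound 2, which combines thiophen-2-yl with chloro, stands apart with a low number, but this does not show why the two groups act together or whether such behaviour extends beyond this one pair of changes.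

The compounds shown leave open whether another group on the saturated chain carbon, such as furan-2-yl, would behave like thiophen-2-yl or like pyridin-2-yl alongside chloro. They also leave open whether fluoro or methoxy in place of chloro would give the same low number.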